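The source may report more compounds than this note shows. Statements on the series, on what has been measured and on what is new or still open speak of the compounds shown alone.

Compound 1 `CCc1ccc(CN[C@@H]2C[C@H]3C[C@@H]([C@H]2C)C3(C)C)s1` in an ADME assay on MDCK cells (Canis lupus familiaris) for cytotoxicity, read by microscopy, with a stated time of 48 h (on this read-out lower numbers stand for higher toxicity in this test and higher numbers for lower toxicity in this test), gives 1560 nM.
Compound 2 `C[C@H]1[C@H](NCc2sccc2-c2ccsc2)C[C@H]2C[C@@H]1C2(C)C` in this assay gives 12500 nM.
Compound 3 `C[C@H]1[C@H](NCc2cc(C3CC3)cs2)C[C@H]2C[C@@H]1C2(C)C` in this assay gives 25000 nM.

Among the three compounds measured, compound 1 stands at the lowest number in this assay, and therefore at the highest cytotoxicity of the set. Among the measured compounds shown here, its nearest neighbour is compound 2, whose number is higher by a margin beyond the usual scatter, and compound 3 lies further still above it; no single-point step between these measured compounds is available, so only the bare values can be compared.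

Compound 4 `Cc1ccc(CN[C@@H]2C[C@H]3C[C@@H]([C@H]2C)C3(C)C)s1` has not been measured. It differs from compound 1 in one place: hydrogen in place of methyl on a saturated chain carbon bound to an aromatic carbon. For the measured compounds named here, no measured pair shows the effect of this change, so the expectation rests on the small size of the difference alone. In this assay the step is expected to be small, and most likely no change beyond the scatter, with at most a slight move toward a higher number. Compound 4 is accordingly estimated at 2000 nM, in a range from 800 nM to 6000 nM, which amounts to an expected step of a 1.3-fold higher number from compound 1 to compound 4 (0.11 log units; within the scatter).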

Compound 4, minimum cytotoxic concentration: 780 nM
The estimate for compound 4 lay 2.6-fold (0.41 log units) above the measured number; measured number below the stated range.
By their numbers in this assay, from the lowest: compounds 4 and 1 (each within the scatter of the next); then compounds 2 and 3 (each within the scatter of the next).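

In this assay, the change from ethyl to methyl, which is hydrogen in place of methyl on a saturated chain carbon bound to an aromatic carbon, gives a 2.0-fold lower number from compound 1 to compound 4 (0.30 log units; within the scatter). Among the compounds shown here, this is the first comparison in the set between compounds that differ in only one place, and it shows that this small change to the group leaves the two numbers within the scatter of each other. Nothing available explains this result.

For the compounds shown here, with only ethyl and methyl compared at this place, the single pair establishes no trend across chain lengths. Going by these compounds, what a longer chain such as propyl, a hydroxymethyl group or a carboxylic acid at this place would do in this assay remains open.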